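Pyridin-2-yl to Phenyl: a Step toward a Weak Cytotoxin

A few compounds are considered here, and "the series" means these few. Any claim that something is new, unique, unknown or untested is made for them only; others in the source may bear on it.

Measured in a functional assay on KB 3-1 cells (Homo sapiens) for cytotoxicity, read by MTT assay, with a stated time of 68 h; a lower number here means a stronger inhibitor, a higher number a weaker inhibitor:
compound 1 `O=C(Nc1cccc(-c2ccc(F)cc2)c1)C(Cl)Cl` — 26200 nM
compound 2 `O=C(Nc1cccc(-c2nccs2)c1)C(Cl)Cl` — > 50000 nM
compound 3 `O=C(Nc1cccc(-c2ccccn2)c1)C(Cl)Cl` — > 50000 nM

Compound 3 has no number in this assay but only a limit, > 50000 nM. This is the limit of > 50000 nM in this assay, at which 2 of the 3 values shown sit. Compound 2 likewise reaches only a limit, > 50000 nM. The one step among these, a step that the two limits leave unreadable from compound 2 to compound 3, therefore cannot be read. Among the compounds with values here, compound 1, whose phenyl carries a fluorine, is the only one with a number; in this assay compound 1 gives 26200 nM.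

Compound 4 `O=C(Nc1cccc(-c2ccccc2)c1)C(Cl)Cl` differs from compound 3 in one place: phenyl in place of pyridin-2-yl on an aromatic carbon. Within the data shown here, no measured step touches this exchange, so its size cannot be taken from the data. The nearest point of reference is compound 1, whose value 26200 nM shows that a carbon-only ring at this position can give a readable number. Compound 4 is expected near compound 1, at an estimated 30000 nM, with a range from 10000 nM to 80000 nM. The expected step of an at least 1.6-fold lower number from compound 3 to compound 4 (0.22 log units; that floor lies within the scatter) starts from a limit and therefore carries no readable size.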

Compound 4, half-maximal inhibitory concentration: 46800 nM
Beside the measured number, compound 4's estimate is 1.6-fold (0.19 log units) below it; low and high end bracket the measured number.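

With phenyl at this position, compound 4 gives a number in this assay, so a readable value does not depend on the fluorine of compound 1. Hydrogen in place of fluoro gives a 1.8-fold higher number from compound 1 to compound 4 (0.25 log units; within the scatter), and the two compounds cannot be told apart in this assay. Phenyl in place of pyridin-2-yl gives an at least 1.0-fold lower number from compound 3 to compound 4 (0.02 log units; that floor lies within the scatter), and phenyl in place of 1,3-thiazol-2-yl gives an at least 1.0-fold lower number from compound 2 to compound 4 (0.02 log units; that floor lies within the scatter), but both steps start from a limit and show only a floor, so neither exchange has a readable size: the limit of > 50000 nM in this assay, at which 2 of the 4 values shown sit.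

Still open, going by these compounds, is whether an amine or a carboxylic acid on the phenyl ring would shift the number beyond the scatter. Also open, on these data alone, is how a longer chain in place of the dichloromethyl group would read in this assay.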